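Phenyl substitution: from compound 3 to compound 4

A few compounds are considered here, and "the series" means these few. Any claim that something is new, unique, unknown or untested is made for them only; others in the source may bear on it.

Compound 1 `O=C(Nc1ccc(-c2cscn2)cc1)C1CCCN(C(=O)c2ccc(F)c(F)c2)C1`: > 20000 nM
Compound 2 `O=C(Nc1ccc(-c2cscn2)cc1)C1CCCN(Cc2ccc(F)cc2)C1`: 5000 nM
Compound 3 `O=C(Nc1ccc(-c2cscn2)cc1)C1CCCN(Cc2cc(F)cc(F)c2)C1`: 1500 nM
Compound 4 `O=C(Nc1ccc(-c2cscn2)cc1)C1CCCN(Cc2ccc(Cl)c(Cl)c2)C1`: not yet measured

Within the data shown here, in a functional assay on A-375 cells (Homo sapiens) for activation, with a stated time of 3 days (on this read-out lower numbers stand for an effect already at smaller amounts and higher numbers for an effect only at larger amounts of compound), compound 3 gives 1500 nM, the lowest of the numbers so far. Compound 1 gives > 20000 nM, which is a limit of the assay and not a number.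

The next change is 3,4-dichlorophenyl in place of 3,5-difluorophenyl on a saturated chain carbon bound to an amine nitrogen in a ring. In words, this is 3,4-dichlorophenyl in place of 3,5-difluorophenyl on a saturated chain carbon bound to an amine nitrogen in a ring. The steps of an at least 4.0-fold lower number from compound 1 to compound 2 (0.60 log units; beyond the scatter) and an at least 13-fold lower number from compound 1 to compound 3 (1.12 log units; beyond the scatter) replace the carbonyl link, which stays untouched here, so they bear on this change only indirectly. Among the measured compounds shown here, the closest precedent is a 3.3-fold lower number from compound 2 to compound 3 (0.52 log units; beyond the scatter), the one measured step that alters the substituted phenyl itself. For the measured compounds named here, no measured compound carries chlorine, so that precedent is only a rough guide.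

In this assay a step no larger than that modest one is expected, leaning toward a lower number, and it may well stay within the scatter. The estimated step is a 1.3-fold lower number from compound 3 to compound 4 (0.10 log units; within the scatter). For compound 4 the expected value is 1200 nM, with an estimated range of 300 nM to 5000 nM.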

Compound 4, half-maximal effective concentration: 3000 nM
Compound 4: the middle estimate sits 2.5-fold (0.40 log units) below what was measured, and the stated range covers the measured number.
By their numbers in this assay, from the lowest: compounds 3, 4 and 2 (each within the scatter of the next, the first and the last beyond it). At a limit, above all of these: compound 1.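

In this assay, among these compounds, the first chlorine-bearing group at this place gives a 2.0-fold higher number from compound 3 to compound 4 (0.30 log units; within the scatter) and a 1.7-fold lower number from compound 2 to compound 4 (0.22 log units; within the scatter), so compound 4 lies within the scatter of both compound 3 and compound 2, even though the step between those two, a 3.3-fold lower number from compound 2 to compound 3 (0.52 log units; beyond the scatter), lies beyond it. The phenyl on the benzyl link therefore accepts chlorine in place of fluorine, and the change leaves the number in the same band as the two fluorinated benzyl compounds. All three benzyl compounds now separate from the carbonyl-linked compound 1, with an at least 6.6-fold lower number from compound 1 to compound 4 (0.82 log units; beyond the scatter), though that step is only a bound, set by a value that is a limit of the assay and not a number: the limit of > 20000 nM in this assay, at which 1 of the 4 values shown sits.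

The change from compound 3 to compound 4 alters the halogen and its placement at once, so the effect of each remains unresolved; 3,5-dichlorobenzyl and 3,4-difluorobenzyl would separate the two. Also open, going by these compounds, is how this place responds to groups other than halogens, such as methoxy, trifluoromethyl or a carboxylic acid on the phenyl, or a pyridine in place of the phenyl.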